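The source may hold more compounds than are shown below. What is called first, only, known or untested is meant among the compounds shown, and "the series" means these compounds.

Compound 2 `CC(C)NC(=O)[C@H]1CC[C@@H](n2/c(=N/C(=O)c3ccc(F)cc3)[nH]c3ccc(CN4CC(C(C)(C)O)C4)cc32)CC1` stands at the floor of the two numbers shown. In an in vitro ADME assay on microsomes from liver (Rattus norvegicus) for metabolic stability (a higher number here means faster removal of the compound, a lower number slower removal), compound 2 gives < 14 mL.min-1.g-1, which is a limit of the assay and not a measured number. Its neighbour, compound 1 `CC(C)NC(=O)[C@H]1CC[C@@H](n2/c(=N/C(=O)c3ccc(F)cc3)[nH]c3ccc(CN4CCC[C@H]4C(C)(C)O)cc32)CC1`, carries 2-(1-hydroxy-1-methylethyl)pyrrolidin-1-yl at the same place and in this assay compound 1 gives 455 mL.min-1.g-1. Within the data shown here, the one measured step is an at least 32-fold lower number from compound 1 to compound 2 (1.51 log units; beyond the scatter), and it is bounded only on one side because of the limit of < 14 mL.min-1.g-1 in this assay, at which 1 of the 2 values shown sits.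

Compound 3 `CC(C)NC(=O)[C@H]1CC[C@@H](n2/c(=N/C(=O)c3ccc(F)cc3)[nH]c3ccc(CN4CCCCC4)cc32)CC1` differs from compound 2 as follows: piperidin-1-yl in place of 3-(1-hydroxy-1-methylethyl)azetidin-1-yl on a saturated chain carbon bound to an aromatic carbon. No measured step matches this change, since the only step shown swaps one hydroxyalkyl-bearing ring for another; it tells merely that the choice of ring at this saturated chain carbon moved the read-out by a large amount. On that basis a rise of comparable order is expected rather than none, so that the step of an at least 10-fold higher number from compound 2 to compound 3 (1.02 log units; beyond the scatter) is the estimate. Compound 3 is expected to give about 150 mL.min-1.g-1 in this assay, with a range from 35 mL.min-1.g-1 to 650 mL.min-1.g-1.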

Compound 3, intrinsic clearance in microsomes: 451 mL.min-1.g-1
Beside the measured number, compound 3's estimate is 3.0-fold (0.48 log units) below it; the range from low to high includes it.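

In this assay, piperidin-1-yl in place of 3-(1-hydroxy-1-methylethyl)azetidin-1-yl gives an at least 32-fold higher number from compound 2 to compound 3 (1.50 log units; beyond the scatter), so compound 2 now stands apart from two neighbours rather than one. Piperidin-1-yl in place of 2-(1-hydroxy-1-methylethyl)pyrrolidin-1-yl gives a 1.0-fold lower number from compound 1 to compound 3 (0.00 log units; within the scatter), so a ring without the 1-hydroxy-1-methylethyl group and a ring with it sit level here, and compound 1 shows that carrying this group does not by itself go with a low number. The size of the step to compound 3 is open on one side, because compound 2 stands at a limit of the assay and not at a measured number: the limit of < 14 mL.min-1.g-1 in this assay, at which 1 of the 3 values shown sits.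

As far as these compounds go, what stays open is whether the low number of compound 2 goes with the four-membered ring alone or with that ring and its 1-hydroxy-1-methylethyl group together. Plain azetidin-1-yl on the same saturated chain carbon would separate the two, while the true distance of compound 2 from the other compounds remains unknown.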